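A few compounds are considered here, and "the series" means these few. Any claim that something is new, unique, unknown or untested is made for them only; others in the source may bear on it.

Compound 1 `CCCNC(=C\C(=O)/C=C/c1ccc(O)c(OC)c1)/C=C/c1ccc(O)c(OC)c1`: > 25000 nM
Compound 2 `CC(C)CNC(=C\C(=O)/C=C/c1ccc(O)cc1)/C=C/c1ccc(O)cc1`: 17900 nM
Compound 3 `COc1cc(/C=C/C(=O)/C=C(/C=C/c2ccc(OC(C)=O)c(OC)c2)NCC(C)C)ccc1OC(C)=O`: > 25000 nM

In a functional assay on CHO-K1 cells (Cricetulus griseus) for inhibition, read by MTT assay, with a stated time of 72 h (on this read-out higher numbers stand for weaker inhibition and lower numbers for stronger inhibition), compound 1 gives > 25000 nM, which is a limit of the assay and not a number. Compound 1 thus stands at the limit of > 25000 nM in this assay, at which 2 of the 3 values shown sit. Compound 2 alone gives a true number, 17900 nM.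

Compound 4 `COc1cc(/C=C/C(=O)/C=C(/C=C/c2ccc(O)c(OC)c2)NC2CCCCC2)ccc1O` keeps the core of compound 1 but has cyclohexyl in place of propyl on an amine nitrogen. Among the compounds with values here, no measured pair shows this change on its own, so the expectation is loose. The expected change, an at least 1.3-fold lower number from compound 1 to compound 4 (0.14 log units; that floor lies within the scatter), is small and points toward stronger inhibition in this assay, and the result may again be only a limit. Compound 4 is estimated at 18000 nM, with an expected range of 8000 nM to 35000 nM.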

Compound 4, half-maximal inhibitory concentration: 24700 nM
Compound 4: the middle estimate sits 1.4-fold (0.14 log units) below what was measured; measured number inside the range.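

In this assay the change from propyl to cyclohexyl on this amine nitrogen gives an at least 1.0-fold lower number from compound 1 to compound 4 (0.00 log units; that floor lies within the scatter) and so shows no shift that stands clear of the usual scatter. Going by these compounds, compound 4 gives a true number where compound 1 has only a limit, so the real size of this step stays unknown: the limit of > 25000 nM in this assay, at which 2 of the 4 values shown sit.

The compounds shown leave open whether a benzyl group or a chain ending in an amine on this nitrogen would give a clearly lower number. They also leave open how much the ring itself contributes.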